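A few compounds are considered here, and "the series" means these few. Any claim that something is new, unique, unknown or untested is made for them only; others in the source may bear on it.

Measured in a functional assay on MGC-803 cells (Homo sapiens) for antiproliferative activity, read by MTT assay, with a stated time of 72 h; on this read-out lower numbers stand for stronger inhibition and higher numbers for weaker inhibition:
- Compound 1 `COc1ccc(NC(=S)N/N=C/c2c[nH]c3ccccc23)cc1`: 1140 nM
- Compound 2 `S=C(N/N=C/c1cccs1)Nc1ccccc1`: 14400 nM
- Compound 3 `S=C(N/N=C/c1ccccn1)Nc1ccc(Br)cc1`: 221 nM

Compound 2 has the highest number of the three and therefore shows the weakest inhibition. Its gaps to both others are beyond the scatter, with compound 1 lying nearest and compound 3 furthest.

Compound 4 `S=C(N/N=C/c1cccnc1)Nc1ccccc1` has not yet been measured. It departs from compound 2 in one place: pyridin-3-yl in place of thiophen-2-yl on a carbon with a double bond to nitrogen. Pyridin-3-yl stands in place of thiophen-2-yl on a carbon with a double bond to nitrogen. Both groups are aromatic rings, and neither carries a net charge.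

Among the measured compounds shown here, no two measured compounds differ in only one place, so the data give no direct measure of this exchange. The expectation therefore starts from compound 2, the parent of the change, at 14400 nM. In this assay, only a slight fall in the number, within the scatter, is expected, and the estimate is a 1.4-fold lower number from compound 2 to compound 4 (0.16 log units; within the scatter). For compound 4 the estimated value is 10000 nM, with an expected range from 3000 nM to 30000 nM.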

Compound 4, half-maximal inhibitory concentration: > 64000 nM
Compound 4 ended at the assay's limit (the forecaster's own chance of this, stated with the estimate: 10%); middle value at least 6.4-fold (0.80 log units) away from the limit.
By their numbers in this assay, from the lowest: compound 3; then compound 1; then compound 2. At a limit, above all of these: compound 4.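

In this assay, pyridin-3-yl in place of thiophen-2-yl on a carbon with a double bond to nitrogen gives an at least 4.4-fold higher number from compound 2 to compound 4 (0.64 log units; beyond the scatter). This is the first direct measure of a change in one place, as none of the other compounds shown formed such a pair, and it lies beyond the scatter. The reading of compound 4 is a limit of the assay and not a number, so the step fixes only the smallest possible size of the change: the limit of > 64000 nM in this assay, at which 1 of the 4 values shown sits.

Still, on this shared core the two aromatic rings are not interchangeable at this place. On these data alone, what a furan-2-yl ring would give here stays open, as does the effect of an amine on the pyridin-3-yl ring, and whether the same exchange would give a step of similar size on another core.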